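The source may hold more compounds than are shown below. What is called first, only, known or untested is meant among the compounds shown, and "the series" means these compounds.

Compound 1 `OC[C@H]1O[C@@H](O[C@H]2c3ccc(O)cc3O[C@@H](c3ccc(O)cc3)[C@@H]2O)[C@H](O)[C@@H](O)[C@@H]1O`: 51500 nM
Compound 2 `COc1cc([C@@H]2Oc3cc(CCCO)cc(O)c3O[C@H]2CO)ccc1O[C@@H]1O[C@H](CO)[C@@H](O)[C@H](O)[C@H]1O`: 50600 nM

In a functional assay on BV-2 cells (Mus musculus) for inhibition (a lower number here means a stronger inhibitor, a higher number a weaker inhibitor), compound 2 gives the lower of the two numbers, while compound 1 lies within the scatter of it, so the two stand level. Compound 3 `COc1cc([C@@H]2Oc3cc(CCCO)cc(O)c3O[C@H]2CO)ccc1O` differs from compound 2 in one place: hydrogen in place of 3,4,5-trihydroxy-6-(hydroxymethyl)oxan-2-yl on an oxygen on an aromatic ring. For the measured compounds named here, no pair of compounds with values in hand shows what this change does, so the author has nothing to lean on here. The author therefore expects a step from compound 2 to compound 3 of a 1.3-fold lower number from compound 2 to compound 3 (0.10 log units; within the scatter), with no firm direction beyond the scatter. The estimate for compound 3 in this assay is 40000 nM, with a range from 10000 nM to 150000 nM.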

Compound 3, half-maximal inhibitory concentration: 36900 nM
Compound 3: the middle estimate sits 1.1-fold (0.04 log units) above what was measured, and the stated range covers the measured number.
By their numbers in this assay, from the lowest: compounds 3, 2 and 1 (each within the scatter of the next).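

In this assay, replacing the 3,4,5-trihydroxy-6-(hydroxymethyl)oxan-2-yl on the oxygen on an aromatic ring with hydrogen gives a 1.4-fold lower number from compound 2 to compound 3 (0.14 log units; within the scatter) and so leaves the two compounds level. For the compounds shown here, this is the first reading of this change, and it shows that inhibition at this level does not depend on that group at this position. No measurement at hand explains the outcome. From the compounds shown here alone, whether a methyl, a longer chain or an amine-bearing chain on this oxygen would move the number beyond the scatter stays open.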